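Phenyl for Isopropyl: Expectation for Compound 3

The source may report more compounds than this note shows. Statements on the series, on what has been measured and on what is new or still open speak of the compounds shown alone.

Compound 1 `CCc1cc(Cc2cccc(OC)c2)c(=O)n(CC(=O)Nc2ccc(I)cc2)n1`: > 50000 nM
Compound 2 `COc1cccc(Cc2cc(C(C)C)nn(CC(=O)Nc3ccc(Br)cc3)c2=O)c1`: > 50000 nM

Of the compounds shown here, two have so far been tested in a functional assay on HL-60 cells (Homo sapiens), read by calcium flux; a higher number here means that more compound is needed for the effect, a lower number that less compound is needed. Compound 1 gives > 50000 nM, which is a limit of the assay and not a number. Compound 2 gives > 50000 nM, likewise a limit and not a number. For the measured compounds named here, compound 2 therefore stands at the limit of > 50000 nM in this assay, at which 2 of the 2 values shown sit, and the two values together show only that both compounds sit at that limit; no step between them can be sized.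

Compound 3 `COc1cccc(Cc2cc(-c3ccccc3)nn(CC(=O)Nc3ccc(Br)cc3)c2=O)c1` differs from compound 2 in one place: phenyl in place of isopropyl on an aromatic carbon. Going by the values given here, no measured step between these two compounds exists, so no direction can be read from the numbers. With compound 2 at a limit, the step to compound 3 in this assay can be expected only as none beyond the scatter, with some chance that a measurable value emerges. Compound 3 is therefore estimated at 40000 nM, in a range from 5000 nM to 200000 nM, which means an expected step of an at least 1.2-fold lower number from compound 2 to compound 3 (0.09 log units; that floor lies within the scatter).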

Compound 3, half-maximal effective concentration: > 50000 nM
Compound 3 was reported as a limit; the forecaster's own chance of this, stated with the estimate: 70%; middle value at least 1.2-fold (0.09 log units) from the limit.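

In this assay compound 3 gives > 50000 nM, a limit of the assay and not a number. Compound 2 also stands at a limit, so no step between compound 2 and compound 3 can be read: the limit of > 50000 nM in this assay, at which 3 of the 3 values shown sit.

The compounds shown leave open what phenyl in place of isopropyl changes, as none of them has yet given a measurable value.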